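The source may hold more compounds than are shown below. What is called first, only, known or untested is meant among the compounds shown, and "the series" means these compounds.

Compound 1 `Nc1scc(CN2CCN(c3ccc(Cl)cc3Cl)CC2)c1C(=O)c1ccc(Cl)cc1`: -11%
Compound 2 `Nc1scc(CN2CCN(c3cccnc3)CC2)c1C(=O)c1ccc(Cl)cc1`: 3.4%
Compound 3 `Nc1scc(CN2CCN(c3ccc(F)cc3F)CC2)c1C(=O)c1ccc(Cl)cc1`: -17%

In a functional assay on CHO cells with adenosine receptor A1 (Homo sapiens) as the target, read by cAMP accumulation and immunoassay, with a stated time of 6 min, tested at 0.1 uM (a higher number here means a weaker effect of the compound at the concentration tested, a lower number a stronger effect), compound 3 has the lowest of the three numbers. The step of a number 6 percentage points lower from compound 1 to compound 3 (within the scatter) lies within the scatter, so compound 1 sits closest; the step of a number 20.4 percentage points lower from compound 2 to compound 3 (beyond the scatter) lies beyond it, so compound 2 sits furthest away.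

Compound 4 `Nc1scc(CN2CCN(c3cc(Cl)ccc3Cl)CC2)c1C(=O)c1ccc(Cl)cc1` differs from compound 3 in one place: 2,5-dichlorophenyl in place of 2,4-difluorophenyl on an amine nitrogen in a ring. The step that bears on this change is a number 6 percentage points lower from compound 1 to compound 3 (within the scatter), where two chlorines gave way to two fluorines on the same ring without leaving the scatter; only the pyridin-3-yl step a number 14.4 percentage points higher from compound 1 to compound 2 (beyond the scatter) moved the number beyond it. Returning to two chlorines, now as 2,5-dichlorophenyl, is expected to give a small step of a number 5 percentage points higher from compound 3 to compound 4 (within the scatter), likely within the scatter. Compound 4 is estimated at -12%, between -30% and 8%.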

Compound 4, a percentage reported as activity, at one concentration (the size of the read-out at that concentration, not a potency): -6.2%
Beside the measured number, compound 4's estimate is 5.8 percentage points below it; measured number inside the range.
By their numbers in this assay, from the lowest: compounds 3, 1, 4 and 2 (each within the scatter of the next, the first and the last beyond it).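

In this assay, 2,5-dichlorophenyl in place of 2,4-difluorophenyl gives a number 10.8 percentage points higher from compound 3 to compound 4 (beyond the scatter), so exchanging one dihalophenyl group for another on this amine nitrogen can leave the scatter, which the earlier swap of chlorines for fluorines did not do. The two dichlorophenyl patterns remain unresolved at a number 4.8 percentage points higher from compound 1 to compound 4 (within the scatter), and the comparison with pyridin-3-yl, at a number 9.6 percentage points lower from compound 2 to compound 4 (within the scatter), also stays within the scatter. Nothing available accounts for these steps.

Going by these compounds, how a benzyl or 4-methoxyphenyl group on the same ring nitrogen would read remains open. So does whether these small steps persist at other concentrations.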